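This account rests on a few compounds, and the source may have more. Where it says the series, first, only, none or still open, it means among the compounds named here.

Series notes. In a functional assay on RAW264.7 cells (Mus musculus) for inhibition, read by immunoassay, with a stated time of 12 h, tested at 30 uM (a lower number here means less inhibition, a higher number more inhibition at the concentration tested (going by the name of the read-out)), compound 1 `O=C1CC(c2ccccc2OCc2ccc(F)cc2)Oc2ccccc21` gives 45.2%, compound 2 `CCCCCOc1ccccc1C1CC(=O)c2ccccc2O1` gives 41.3% and compound 3 `CCCCOc1ccccc1C1CC(=O)c2ccccc2O1` gives 19.3%. Compound 3 stands lowest of the three numbers, with a number 22 percentage points lower from compound 2 to compound 3 (beyond the scatter) and a number 25.9 percentage points lower from compound 1 to compound 3 (beyond the scatter) both beyond the scatter, while a number 3.9 percentage points lower from compound 1 to compound 2 (within the scatter) stays within it. Compound 4 `O=C1CC(c2ccccc2OCc2ccccc2)Oc2ccccc21` differs from compound 3 by phenyl in place of propyl on a saturated chain carbon bound to an oxygen on an aromatic ring. The measured step that bears most directly on this change is a number 25.9 percentage points lower from compound 1 to compound 3 (beyond the scatter), which runs the other way, from an aromatic ring to a chain at the same place; read in reverse it points to a modest rise in this assay. For compound 4 the expected step is a number 22.7 percentage points higher from compound 3 to compound 4 (beyond the scatter). Compound 4 is therefore expected to give 42%, within a range of 28% to 56%.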

Compound 4, a percentage reported as inhibition, at one concentration (the size of the read-out at that concentration, not a potency): 93.2%
Beside the measured number, compound 4's estimate is 51.2 percentage points below it, and the stated range ends below it.
By their numbers in this assay, from the lowest: compound 3; then compounds 2 and 1 (each within the scatter of the next); then compound 4.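

At this place the aromatic ring now separates clearly from the chains in this assay: phenyl in place of propyl gives a number 73.9 percentage points higher from compound 3 to compound 4 (beyond the scatter), and phenyl in place of butyl gives a number 51.9 percentage points higher from compound 2 to compound 4 (beyond the scatter). The fluoro on the aromatic carbon, which compound 1 alone carries, also matters, since hydrogen in its place gives a number 48 percentage points higher from compound 1 to compound 4 (beyond the scatter). No evidence bearing on the cause of these steps is at hand. Still open, from the compounds shown here alone, is whether chloro or methoxy on that aromatic carbon would track compound 1 or compound 4, and how an amine on the ring would read.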